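A second fluoro on compound 2

The source may hold more compounds than are shown below. What is called first, only, known or untested is meant among the compounds shown, and "the series" means these compounds.

In an in vitro ADME assay on microsomes from liver (Mus musculus) for pharmacokinetics, read by LC-MS, with a stated time of 10 min, tested at 1 uM (on this read-out higher numbers stand for fast clearance and lower numbers for slow clearance), compound 1 `CN1C[C@H](C(=O)Nc2ccc(C(F)(F)F)cc2)[C@@H](c2ccc(/C=C/C(=O)Nc3ccccc3N)cc2)C1` gives 23 mL/min/kg, and compound 2 `CN1C[C@H](C(=O)Nc2ccccc2F)[C@@H](c2ccc(/C=C/C(=O)Nc3ccccc3N)cc2)C1` gives 67 mL/min/kg, the higher of the two numbers. Compound 3 `CN1C[C@H](C(=O)Nc2ccc(F)cc2F)[C@@H](c2ccc(/C=C/C(=O)Nc3ccccc3N)cc2)C1` is compound 2 with one change, fluoro in place of hydrogen on an aromatic carbon. Going by the values given here, only one measured step bears on this change, a 2.9-fold higher number from compound 1 to compound 2 (0.46 log units; beyond the scatter), which is modest but beyond the scatter. It swaps 4-(trifluoromethyl)phenyl for 2-fluorophenyl, so it offers only a weak hint that the new group could lower the number. The expected step is small and downward, within the scatter: a 1.3-fold lower number from compound 2 to compound 3 (0.13 log units; within the scatter). For compound 3, the estimated value is 50 mL/min/kg, with a range of 25 mL/min/kg to 90 mL/min/kg.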

Compound 3, clearance: 27 mL/min/kg
For compound 3 the middle estimate is 1.9-fold (0.27 log units) above the measured one, and the stated range covers the measured number.
By their numbers in this assay, from the lowest: compounds 1 and 3 (each within the scatter of the next); then compound 2.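

In this assay, adding fluoro on the aromatic carbon para to a large group gives a 2.5-fold lower number from compound 2 to compound 3 (0.39 log units; beyond the scatter) and shows that this single position can shift the read-out, which the earlier whole-group swap could not isolate. The 2,4-difluorophenyl group also performs on a par with 4-(trifluoromethyl)phenyl, with a 1.2-fold higher number from compound 1 to compound 3 (0.07 log units; within the scatter) as the step between them. Nothing available explains why the number moves.

As far as these compounds go, whether chloro, methoxy or an amine at this position would act like fluoro remains open. So does how 4-fluorophenyl alone would compare.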